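The source may hold more compounds than are shown below. What is called first, only, known or untested is meant among the compounds shown, and "the series" means these compounds.

Measured compounds:
compound 1 `CCCCCCOc1nc(C(C)(C)C)ccc1CNC(=O)C(C)c1ccc(NS(C)(=O)=O)c(F)c1`, 2.7 nM
compound 2 `CC(C(=O)NCc1ccc(C(C)(C)C)nc1OCc1ccc(F)cc1)c1ccc(NS(C)(=O)=O)c(F)c1`, 0.8 nM

Going by the values given here, in an assay on cells for antagonist activity at transient receptor potential cation channel subfamily V member 1 (Homo sapiens), read by FLIPR and calcium flux, with a stated time of 6 min (on this read-out higher numbers stand for weaker inhibition and lower numbers for stronger inhibition), compound 2 gives the lower of the two numbers, and the only measured step is a 3.4-fold lower number from compound 1 to compound 2 (0.53 log units; beyond the scatter). Compound 3 `CC(C(=O)NCc1ccc(C(C)(C)C)nc1SCc1ccccc1Cl)c1ccc(NS(C)(=O)=O)c(F)c1` differs from compound 2 in one place: (2-chlorobenzyl)sulfanyl in place of (4-fluorobenzyl)oxy on an aromatic carbon. Among the compounds with values here, no measured step exchanges the oxygen for sulfur or moves the halogen on the benzyl ring, so the one step from compound 1 to compound 2 bears on this change only loosely. The number for compound 3 in this assay is therefore expected to lie close to that of compound 2, with a step of a 1.9-fold higher number from compound 2 to compound 3 (0.27 log units; within the scatter) estimated. Compound 3 is estimated at 1.5 nM, between 0.4 nM and 6 nM.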

Compound 3, inhibition constant: 3.8 nM
The estimate for compound 3 lay 2.5-fold (0.40 log units) below the measured number, and the stated range covers the measured number.
By their numbers in this assay, from the lowest: compound 2; then compounds 1 and 3 (each within the scatter of the next).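

In this assay, this exchange at the aromatic carbon is not neutral: the change to (2-chlorobenzyl)sulfanyl from (4-fluorobenzyl)oxy gives a 4.8-fold higher number from compound 2 to compound 3 (0.68 log units; beyond the scatter). Set against hexyloxy, the same (2-chlorobenzyl)sulfanyl group gives a 1.4-fold higher number from compound 1 to compound 3 (0.15 log units; within the scatter), and the lower number of compound 2 is therefore not shared by this second benzyl-bearing group. Nothing given here accounts for the result.

The sulfur and the chlorine enter together, and the compounds shown do not separate their contributions. On these data alone, how an amine or a carboxylic acid on this carbon would read remains open.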